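The source may report more compounds than this note shows. Statements on the series, on what has been measured and on what is new or still open speak of the compounds shown alone.

Series notes. Compound 3 `Cc1ccc(-c2nnn(CC(=O)Nc3cc(C)nn3C3CCCCC3)n2)cc1` gives 111 nM in an assay on HEK293 cells for activation of Kir3.1/Kir3.2 (Homo sapiens), read by thallium flux; a higher number here means that more compound is needed for the effect, a lower number that less compound is needed. Among the three numbers it stands second highest: compound 2 `Cc1cc(NC(=O)Cn2nnc(-c3cccc(F)c3)n2)n(C2CCCCC2)n1` gives 81 nM, and a 1.4-fold higher number from compound 2 to compound 3 (0.14 log units; within the scatter); compound 1 `Cc1cc(NC(=O)Cn2nnc(-c3cc(Cl)cc(Cl)c3)n2)n(C2CCCCC2)n1` gives 980 nM, and an 8.8-fold lower number from compound 1 to compound 3 (0.95 log units; beyond the scatter). Compound 4 `Cc1cc(NC(=O)Cn2nnc(-c3ccc(Cl)c(C)c3)n2)n(C2CCCCC2)n1` carries 4-chloro-3-methylphenyl in place of 4-methylphenyl on an aromatic carbon. Going by the values given here, the steps that bear on this both start from the one chlorine-bearing ring in the set: a 12-fold lower number from compound 1 to compound 2 (1.08 log units; beyond the scatter) and an 8.8-fold lower number from compound 1 to compound 3 (0.95 log units; beyond the scatter), which leave the 3,5-dichlorophenyl compound 1 with the highest number. Among the compounds with values here, compound 4 brings in a single chlorine while keeping a methyl, a change no measured pair covers directly, so in this assay a modest rise is expected for compound 4, a 2.0-fold higher number from compound 3 to compound 4 (0.30 log units; within the scatter). The estimate for compound 4 is 220 nM, with a range of 70 nM to 700 nM.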

Compound 4, half-maximal effective concentration: 712 nM
Estimate against measurement, compound 4: 3.2-fold (0.51 log units) below, and the stated range ends below it.
By their numbers in this assay, from the lowest: compounds 2 and 3 (each within the scatter of the next); then compounds 4 and 1 (each within the scatter of the next).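

On the ring at this position in this assay, 4-chloro-3-methylphenyl gives a much higher number than 4-methylphenyl (a 6.4-fold higher number from compound 3 to compound 4 (0.81 log units; beyond the scatter)) and 3-fluorophenyl (an 8.8-fold higher number from compound 2 to compound 4 (0.94 log units; beyond the scatter)). A high number is therefore not confined to the 3,5-dichlorophenyl ring: the step to that ring lies within the scatter (a 1.4-fold lower number from compound 1 to compound 4 (0.14 log units; within the scatter)), and among these four compounds the two chlorine-bearing rings, compound 1 and compound 4, give the high numbers. Nothing measured here gives a cause for these steps. Going by these compounds alone, no pair isolates the chlorine from the added ring substitution, and how a methoxy group or a nitrile on this ring would read remains open.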